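A few compounds are considered here, and "the series" means these few. Any claim that something is new, unique, unknown or untested is made for them only; others in the source may bear on it.

Compound 1 `O=C(CN1CCN(c2nnc(Cc3ccccc3)c3ccccc23)CC1)Nc1ccc(F)c(F)c1` gives 2750 nM
Compound 2 `Cc1ccccc1NC(=O)CN1CCN(c2nnc(Cc3ccccc3)c3ccccc23)CC1` gives 17300 nM
Compound 3 `O=C(CN1CCN(c2nnc(Cc3ccccc3)c3ccccc23)CC1)Nc1ccc(Br)cc1` gives 12400 nM

These numbers come from a functional assay on MDA-MB-231 cells (Homo sapiens) for cytotoxicity, read by MTT assay, with a stated time of 72 h; a higher number here means a weaker inhibitor, a lower number a stronger inhibitor. Compound 3 stands within the scatter of compound 2 (a 1.4-fold lower number from compound 2 to compound 3 (0.14 log units; within the scatter)) and clearly off compound 1 (a 4.5-fold higher number from compound 1 to compound 3 (0.65 log units; beyond the scatter)). Compound 4 `O=C(CN1CCN(c2nnc(Cc3ccccc3)c3ccccc23)CC1)Nc1cc(C(F)(F)F)ccc1Cl` has 2-chloro-5-(trifluoromethyl)phenyl in place of 4-bromophenyl on an amide-type nitrogen. Changing this group has so far given modest steps at most, such as (a 6.3-fold higher number from compound 1 to compound 2 (0.80 log units; beyond the scatter)). Within the data shown here, compound 1 is the only measured compound with fluorine on that ring, and compound 4 has fluorine too, though one compound is thin evidence. A modest step to a lower number is therefore expected (a 2.3-fold lower number from compound 3 to compound 4 (0.35 log units; beyond the scatter)). Compound 4 is estimated at 5500 nM with 1800 nM to 16000 nM as the expected range.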

Compound 4, half-maximal inhibitory concentration: 19500 nM
Beside the measured number, compound 4's estimate is 3.5-fold (0.55 log units) below it; measured number above the stated range.
By their numbers in this assay, from the lowest: compound 1; then compounds 3, 2 and 4 (each within the scatter of the next).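

In this assay, a 1.6-fold higher number from compound 3 to compound 4 (0.20 log units; within the scatter) and a 1.1-fold higher number from compound 2 to compound 4 (0.05 log units; within the scatter), so the 2-chloro-5-(trifluoromethyl)phenyl group puts compound 4 level with compound 2 and compound 3, while a 7.1-fold higher number from compound 1 to compound 4 (0.85 log units; beyond the scatter) keeps compound 1 apart. Fluorine on this ring therefore does not by itself go with a lower number: compound 1 fits that link, but compound 4 goes against it. Nothing available explains why the two fluorine-bearing rings differ. Still open, going by these compounds, is whether a phenyl ring with a single fluorine, an amine or a carboxylic acid would match compound 1.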